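Replacing a benzyl group on a fused core: permeability outlook

The source may report more compounds than this note shows. Statements on the series, on what has been measured and on what is new or still open speak of the compounds shown alone.

Compound 1, `COc1ccccc1Oc1ccc2c(NCCCNCc3ccco3)ccnc2c1`, gives 317 10^-6 cm/s in an ADME assay for permeability, using PAMPA, with a stated time of 30 min, at pH 7.4; on this read-out higher numbers stand for higher permeability and lower numbers for lower permeability.
Compound 2, `CC(C)CCc1ccc2c(NCCCNCc3ccco3)ccnc2c1`, gives 23 10^-6 cm/s in this assay.
Compound 3, `Cc1cc(C)cc(Cc2ccc3c(NCCCNCc4ccco4)ccnc3c2)c1`, gives 23 10^-6 cm/s in this assay.

Compound 3 stands level with compound 2 at the digits shown, and the two together are the lowest of the three; the one step between them, no change at the digits printed from compound 2 to compound 3 (within the scatter), lies within the scatter. Against compound 1 the picture differs: a 14-fold lower number from compound 1 to compound 3 (1.14 log units; beyond the scatter), much as a 14-fold lower number from compound 1 to compound 2 (1.14 log units; beyond the scatter). Compound 4, `FC(F)(F)c1ccc(-c2ccc3c(NCCCNCc4ccco4)ccnc3c2)cc1`, is compound 3 with one change: 4-(trifluoromethyl)phenyl in place of 3,5-dimethylbenzyl on an aromatic carbon. Among the compounds with values here, no measured step removes a 3,5-dimethylbenzyl group, so the outcome is uncertain. Compound 2 and compound 3 show the lower level is readily kept, while compound 1 shows a much higher number is possible. Compound 4 is therefore expected to show a modest rise in this assay, a 1.5-fold higher number from compound 3 to compound 4 (0.18 log units; within the scatter), landing near 35 10^-6 cm/s with a range from 8 10^-6 cm/s to 150 10^-6 cm/s.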

Compound 4, apparent permeability: 237 10^-6 cm/s
Compound 4: the middle estimate sits 6.8-fold (0.83 log units) below what was measured, and the stated range ends below it.
By their numbers in this assay, from the lowest: compounds 2 and 3 (each within the scatter of the next); then compounds 4 and 1 (each within the scatter of the next).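

On this aromatic carbon of the shared core, 4-(trifluoromethyl)phenyl reaches the upper level in this assay, with a 10-fold higher number from compound 3 to compound 4 (1.01 log units; beyond the scatter) and a 10-fold higher number from compound 2 to compound 4 (1.01 log units; beyond the scatter). The upper level therefore does not depend on 2-methoxyphenoxy alone, since a 1.3-fold lower number from compound 1 to compound 4 (0.13 log units; within the scatter), and the two groups cannot be told apart here. Nothing measured here explains why these groups fall at two levels.

On these data alone, whether a plain phenyl group, without the trifluoromethyl, would stay at the upper level remains open. So does the outcome for an amine or a carboxylic acid at this position.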